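The source may report more compounds than this note shows. Statements on the series, on what has been measured and on what is new or still open speak of the compounds shown alone.

In a functional assay on A549 cells (Homo sapiens) for antiproliferative activity, read by MTT assay, with a stated time of 24 h (on this read-out higher numbers stand for weaker inhibition and lower numbers for stronger inhibition), compound 2 `COc1cc(-c2cc(/C=C/C(=O)c3ccc(C)c(C)c3)nc3cc(-c4ccccc4)nn23)cc(OC)c1OC` gives 10600 nM, the highest of the three numbers measured, although both of the other compounds sit within the scatter of it: compound 3 `COc1ccc(-c2cc(/C=C/C(=O)c3ccc(C)c(C)c3)nc3cc(-c4ccccc4)nn23)cc1OC` gives 9300 nM and compound 1 `COc1ccc(-c2cc(/C=C/C(=O)c3ccc(OC)c(OC)c3)nc3cc(-c4ccccc4)nn23)cc1` gives 7400 nM. Compound 4 `COc1ccc(C(=O)/C=C/c2cc(-c3cc(OC)c(OC)c(OC)c3)n3nc(-c4ccccc4)cc3n2)cc1` differs from compound 2 by 4-methoxyphenyl in place of 3,4-dimethylphenyl on a carbonyl carbon. Among the compounds with values here, no measured step touches this change; the only measured step, a 1.1-fold lower number from compound 2 to compound 3 (0.06 log units; within the scatter), concerns a different part of the molecule and is within the scatter. Within the data shown here, compound 1 carries the same 4-methoxyphenyl on the carbonyl carbon but also differs from compound 2 elsewhere, so its value shows only that all three compounds lie close together. Compound 4 is therefore expected to show a 1.4-fold lower number from compound 2 to compound 4 (0.15 log units; within the scatter), nothing beyond the scatter. Compound 4 is estimated at 7500 nM, between 3500 nM and 16000 nM.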

Compound 4, half-maximal inhibitory concentration: 14600 nM
Compound 4: middle estimate off by 1.9-fold (0.29 log units), on the low side, within the range that was stated.
By their numbers in this assay, from the lowest: compounds 1, 3, 2 and 4 (each within the scatter of the next).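

Within the data shown here, this step is the first measured change on the carbonyl carbon: in this assay, 4-methoxyphenyl in place of 3,4-dimethylphenyl gives a 1.4-fold higher number from compound 2 to compound 4 (0.14 log units; within the scatter). The two groups therefore cannot be told apart at this position in this assay, so the swap of a methyl-bearing group for a methoxy-bearing one leaves the number within the scatter. Nothing available bears on why the number holds. The compounds shown leave open whether an amine or a carboxylic acid on the phenyl group at this carbonyl carbon would move the number beyond the scatter.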